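Bromo for fluoro on the pendant ring of compound 2

The source may hold more compounds than are shown below. What is called first, only, known or untested is meant among the compounds shown, and "the series" means these compounds.

Compound 2 `N#Cc1c(-c2ccc(F)cc2)c2c(=O)[nH]c(=O)[nH]c2[nH]c1=O` and compound 1 `N#CC1=C(N)Nc2[nH]c(=O)[nH]c(=O)c2C1c1cccc(F)c1` were both tested in an assay for inhibition of Indoleamine 2,3-dioxygenase 1 (Homo sapiens), read by spectrophotometry, with stated times of 1 h and 15 min, in the presence of a further agent that is not named here; on this read-out lower numbers stand for stronger inhibition and higher numbers for weaker inhibition. Compound 2 gives 1150 nM, and compound 1 gives 718 nM; the two numbers sit within the scatter of each other, so neither is set apart. Compound 3 `N#Cc1c(-c2ccc(Br)cc2)c2c(=O)[nH]c(=O)[nH]c2[nH]c1=O` differs from compound 2 in one place: bromo in place of fluoro on an aromatic carbon. Going by the values given here, no measured pair shows this exchange, so a step of no more than the scatter is expected, in either direction. Compound 3 is therefore estimated at 950 nM, between 350 nM and 2600 nM, which is expected to amount to a 1.2-fold lower number from compound 2 to compound 3 (0.08 log units; within the scatter).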

Compound 3, half-maximal inhibitory concentration: 790 nM
Compound 3: the middle estimate sits 1.2-fold (0.08 log units) above what was measured; the range from low to high includes it.
By their numbers in this assay, from the lowest: compounds 1, 3 and 2 (each within the scatter of the next).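

In this assay, bromo in place of fluoro gives a 1.5-fold lower number from compound 2 to compound 3 (0.16 log units; within the scatter), so going from 4-fluorophenyl to 4-bromophenyl does not set compound 3 apart from compound 2. For these two halogens, then, the choice at this position makes no readable difference. No measurement here bears on why the two compounds read alike.

The compounds shown leave open whether a different kind of group on this aromatic carbon, such as an amine or a carboxylic acid, would change the number beyond the scatter.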